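The source may report more compounds than this note shows. Statements on the series, on what has been measured and on what is new or still open speak of the compounds shown alone.

Series notes. Three compounds share one core and differ only at the saturated chain carbon bound to a carbonyl carbon and an oxygen on a saturated carbon. In a functional assay on a cell-free system (plasma, Homo sapiens), with a stated time of 3 min (a higher number here means a weaker inhibitor, a lower number a stronger inhibitor), compound 1 `O=C(NCc1cc(Cl)ccc1-n1cnnn1)[C@@H]1C[C@@H]2C[C@@H]2N1C(=O)[C@H](O)c1ccccc1F` gives 770 nM. Compound 2 `O=C(NCc1cc(Cl)ccc1-n1cnnn1)[C@@H]1C[C@@H]2C[C@@H]2N1C(=O)[C@H](O)c1ccccc1` gives 620 nM in this assay, and the step of a 1.2-fold lower number from compound 1 to compound 2 (0.09 log units; within the scatter) is within the scatter. Compound 3 `CC(C)(C)C[C@@H](O)C(=O)N1[C@H](C(=O)NCc2cc(Cl)ccc2-n2cnnn2)C[C@@H]2C[C@@H]21` gives 570 nM in this assay; its figure is the lowest of the three, but the steps of a 1.4-fold lower number from compound 1 to compound 3 (0.13 log units; within the scatter) and a 1.1-fold lower number from compound 2 to compound 3 (0.04 log units; within the scatter) both stay within the scatter, so the three compounds cannot be told apart on these numbers.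

Compound 4 `CC(C)(C)[C@@H](O)C(=O)N1[C@H](C(=O)NCc2cc(Cl)ccc2-n2cnnn2)C[C@@H]2C[C@@H]21` differs from compound 3 as follows: tert-butyl in place of neopentyl on a saturated chain carbon bound to a carbonyl carbon and an oxygen on a saturated carbon. For the measured compounds named here, the steps that bear on this site are the two that already varied it, a 1.4-fold lower number from compound 1 to compound 3 (0.13 log units; within the scatter) and a 1.1-fold lower number from compound 2 to compound 3 (0.04 log units; within the scatter): exchanging an aromatic group for neopentyl at this carbon moved the number by no more than the scatter. Shortening neopentyl to tert-butyl is a smaller change than either of those, so the expected step of a 1.1-fold higher number from compound 3 to compound 4 (0.02 log units; within the scatter) in this assay is none beyond the scatter, in no set direction. Compound 4 is therefore estimated at 600 nM in this assay, with an expected range from 300 nM to 1200 nM.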

Compound 4, half-maximal inhibitory concentration: 1500 nM
Beside the measured number, compound 4's estimate is 2.5-fold (0.40 log units) below it; the whole stated range lies below it.
By their numbers in this assay, from the lowest: compounds 3, 2, 1 and 4 (each within the scatter of the next, the first and the last beyond it).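

In this assay, for the compounds shown here, this carbon is no longer silent: the steps of a 2.6-fold higher number from compound 3 to compound 4 (0.42 log units; beyond the scatter) and a 2.4-fold higher number from compound 2 to compound 4 (0.38 log units; beyond the scatter) are the first at this position to pass the scatter, though both are modest. The exchange of neopentyl for tert-butyl therefore registers here, whereas the exchanges of phenyl and 2-fluorophenyl for neopentyl did not, so a similar aliphatic group is no guarantee of a similar number at this position, and replacing an aromatic group with an aliphatic one does not by itself set the outcome. The picture is not uniform, since compound 1 goes against it: the step of a 1.9-fold higher number from compound 1 to compound 4 (0.29 log units; within the scatter) stays within the scatter, and compound 1 and compound 4 cannot be told apart on these numbers, while no measurement in hand offers a cause for the tert-butyl result.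

The compounds shown leave open whether a longer chain than neopentyl, or a smaller group such as isopropyl or methyl, would sit with compound 3 or with compound 4 in this assay. They also leave open how an amine or a carboxylic acid on this carbon would read in the same assay.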